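Dropping the Methoxy from a Cyclobutyl Ether

The compounds below may be only part of what the source reports. "The series", "measured", "known", "first", "only" and "open" are said of these compounds alone.

Compound 2 `COc1cc(O[C@H]2C[C@H](OC)C2)cc(-c2ccc3c(c2)CC[C@H]([C@@H]2C[C@H]2C(=O)O)O3)c1F` has been tested in a functional assay on HEK293 cells for agonist activity at Free fatty acid receptor 1 (Homo sapiens), read by HTRF and inositol phosphate accumulation, with a stated time of 60 min; a higher number here means that more compound is needed for the effect, a lower number that less compound is needed. In this assay compound 2 gives > 10000 nM, which is a limit of the assay and not a number. Two other compounds built on the shared core have been measured as well. Compound 1 `CO[C@H]1C[C@H](Oc2cc(F)c(F)c(-c3ccc4c(c3)CC[C@H]([C@@H]3C[C@H]3C(=O)O)O4)c2)C1` gives > 10000 nM in this assay, again a limit. Compound 3 `Fc1ccc(OC(F)(F)F)cc1-c1ccc2c(c1)CC[C@H](CCc1nnn[nH]1)O2` gives > 10000 nM in this assay, also a limit. For the measured compounds named here, the only step between compounds that differ in one place, a step that the two limits leave unreadable from compound 1 to compound 2, exchanges fluoro for methoxy on an aromatic carbon, and the two limits leave its size unreadable. All that the measured set offers is the limit of > 10000 nM in this assay, at which 3 of the 3 values shown sit, which points in no direction.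

Compound 4 `COc1cc(OC2CCC2)cc(-c2ccc3c(c2)CC[C@H]([C@@H]2C[C@H]2C(=O)O)O3)c1F` has not yet been measured. It differs from compound 2 by hydrogen in place of methoxy on a saturated ring carbon: a hydrogen in place of methoxy on a saturated ring carbon, so that (3-methoxycyclobutyl)oxy becomes cyclobutyloxy. Going by the values given here, no measured step bears on this change, and the single known step is itself unreadable. The step expected from this change is a step that the limit leaves unreadable from compound 2 to compound 4, that is none beyond the scatter. For compound 4 the expected value in this assay is 20000 nM, within a range from 5000 nM to 80000 nM, and another limit is considered the most likely result.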

Compound 4, half-maximal effective concentration: > 10000 nM
Compound 4: no number, only a limit; the forecaster's own chance of this, stated with the estimate: 75%; the middle value is on the limit's open side.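

With compound 4, as with compound 2, this assay gives only a limit, so no step can be read from compound 2 to compound 4. The compounds shown leave open whether removing the methoxy changes agonist activity at all, and what any measured value on this series would be, since all of them sit at one limit: the limit of > 10000 nM in this assay, at which 4 of the 4 values shown sit.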